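Chain length at the ester of a cytidine core

The source may report more compounds than this note shows. Statements on the series, on what has been measured and on what is new or still open speak of the compounds shown alone.

Measured so far:
Compound 1 `CCCCCCCCCCCCCCCC(=O)O[C@H]1[C@H](O)[C@H](n2ccc(N)nc2=O)O[C@@H]1CO` gives 0.24 ug/mL in a functional assay on HeLa cells (Homo sapiens) for cytotoxicity, read by cell counting, with a stated time of 48 h; a higher number here means that more compound is needed for the effect, a lower number that less compound is needed.
Compound 2 `CC(=O)O[C@H]1[C@H](O)[C@H](n2ccc(N)nc2=O)O[C@@H]1CO` gives 0.14 ug/mL in this assay.

Compound 2 holds the lowest number of the two, but its gap to compound 1 lies within the usual scatter, so the two values show no difference that can be read. Compound 3 `CCCCCCCCCCCC(=O)O[C@H]1[C@H](O)[C@H](n2ccc(N)nc2=O)O[C@@H]1CO` differs from compound 2 by decyl in place of hydrogen on a saturated chain carbon bound to a carbonyl carbon. Going by the values given here, no step between measured compounds is on hand for this change; since compound 1 and compound 2 sit close together despite their very different ester chains, no shift beyond the scatter is expected in this assay for the step of a 1.4-fold higher number from compound 2 to compound 3 (0.13 log units; within the scatter). Compound 3 is therefore estimated at 0.19 ug/mL in this assay, with a range from 0.08 ug/mL to 0.45 ug/mL.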

Compound 3, concentration for half-maximal effect: 0.08 ug/mL
Compound 3: middle estimate off by 2.4-fold (0.38 log units), on the high side, within the range that was stated.
By their numbers in this assay, from the lowest: compounds 3, 2 and 1 (each within the scatter of the next, the first and the last beyond it).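

In this assay the ester chain now gives a readable difference: the step of a 3.0-fold lower number from compound 1 to compound 3 (0.48 log units; beyond the scatter) lies beyond the scatter and is modest, with hydrogen in place of butyl on a saturated chain carbon. Decyl in place of hydrogen on a saturated chain carbon bound to a carbonyl carbon gives a 1.8-fold lower number from compound 2 to compound 3 (0.24 log units; within the scatter) and stays within the scatter. No supporting measurement accounts for either step.
Open, as far as these compounds go, is how a longer chain, or a chain carrying an amine or a carboxylic acid, would read in this assay on the shared core.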